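Trifluoromethyl in place of nitro: expected step

This account rests on a few compounds, and the source may have more. Where it says the series, first, only, none or still open, it means among the compounds named here.

Measured so far in a functional assay (aorta) with Rattus norvegicus as the target; on this read-out lower numbers stand for an effect already at smaller amounts and higher numbers for an effect only at larger amounts of compound:
compound 1 `CN(C)/C(=N\C#N)C1=CC(C)(C)Oc2ccc([N+](=O)[O-])cc21`: > 31600 nM (a limit)
compound 2 `CN(C)/C(=N\C#N)C1=CC(C)(C)Oc2ccc(C#N)cc21`: 5010 nM
compound 3 `CN(C)/C(=N\C#N)C1=CC(C)(C)Oc2ccc(S(C)(=O)=O)cc21`: > 31600 nM (a limit)

Compound 1 gives no number, only a limit, (the limit of > 31600 nM in this assay, at which 2 of the 3 values shown sit). Compound 4 `CN(C)/C(=N\C#N)C1=CC(C)(C)Oc2ccc(C(F)(F)F)cc21` differs from it by trifluoromethyl in place of nitro on an aromatic carbon. Two measured steps replace the same nitro. The cyano change gives an at least 6.3-fold lower number from compound 1 to compound 2 (0.79 log units; beyond the scatter), while the methylsulfonyl change gives a step that the two limits leave unreadable from compound 1 to compound 3. Compound 3 therefore shows that leaving nitro need not produce a readable gain, and an at least 6.3-fold higher number from compound 2 to compound 3 (0.79 log units; beyond the scatter) separates the two replacements. A modest fall in this assay is expected, though compound 4 may also stay at the limit. The expected change is an at least 2.6-fold lower number from compound 1 to compound 4 (0.42 log units; beyond the scatter). For compound 4 the estimate is 12000 nM, with an expected range of 3000 nM to 31600 nM.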

Compound 4, half-maximal effective concentration: 12600 nM
For compound 4 the middle estimate is 1.1-fold (0.02 log units) below the measured one; the range from low to high includes it.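

At this aromatic carbon in this assay, a second replacement of nitro gives a readable value: an at least 2.5-fold lower number from compound 1 to compound 4 (0.39 log units; beyond the scatter). Trifluoromethyl also clears methylsulfonyl, with an at least 2.5-fold lower number from compound 3 to compound 4 (0.39 log units; beyond the scatter), but does not match the nitrile, with a 2.5-fold higher number from compound 2 to compound 4 (0.40 log units; beyond the scatter). Trifluoromethyl thus sits between the nitrile and the two compounds that give only a limit: the limit of > 31600 nM in this assay, at which 2 of the 4 values shown sit.

From the compounds shown here alone, the true size of the steps from compound 1 and compound 3 remains open. Also open, going by these compounds, is where a chlorine atom or an amine on this carbon would fall relative to the nitrile.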